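Adding a methoxycarbonyl to the benzyl group of compound 2

The source may hold more compounds than are shown below. What is called first, only, known or untested is meant among the compounds shown, and "the series" means these compounds.

Compound 2 `COc1cc2cc(C(=O)CCc3cc[n+](Cc4ccccc4)cc3)sc2cc1OC` holds the lowest of the two numbers in a physicochemical assay for solubility (on this read-out lower numbers stand for lower solubility and higher numbers for higher solubility), giving 2000 ug/mL. Compound 1 `COCC[n+]1ccc(CCC(=O)c2cc3cc(OC)c(OC)cc3s2)cc1` gives 33000 ug/mL. Going by the values given here, the one measured step, a 17-fold lower number from compound 1 to compound 2 (1.22 log units; beyond the scatter), shows how strongly a change on the chain carbon bound to the aromatic nitrogen can move this assay. Compound 3 `COC(=O)c1ccc(C[n+]2ccc(CCC(=O)c3cc4cc(OC)c(OC)cc4s3)cc2)cc1` differs from compound 2 by methoxycarbonyl in place of hydrogen on an aromatic carbon. Among the compounds with values here, no measured step covers a change of this kind, so the expectation rests loosely on compound 2. Compound 3 is expected to give 1200 ug/mL, with a range from 400 ug/mL to 4000 ug/mL, meaning an estimated 1.7-fold lower number from compound 2 to compound 3 (0.22 log units; within the scatter).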

Compound 3, solubility: 3500 ug/mL
Beside the measured number, compound 3's estimate is 2.9-fold (0.46 log units) below it; the measured number falls inside the stated range.
By their numbers in this assay, from the lowest: compounds 2 and 3 (each within the scatter of the next); then compound 1.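

Putting 4-(methoxycarbonyl)benzyl in place of benzyl gives a 1.8-fold higher number from compound 2 to compound 3 (0.24 log units; within the scatter) in this assay, so this addition at the para position of the aromatic ring does not move the number beyond the scatter. Measured against the methoxymethyl chain, the new group still gives a 9.4-fold lower number from compound 1 to compound 3 (0.97 log units; beyond the scatter), so the gap seen with plain benzyl remains. Nothing available explains either step.

Open, as far as these compounds go, is whether an amine or a carboxylic acid at this same place would shift the number beyond the scatter.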